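The source may hold more compounds than are shown below. What is called first, only, known or untested is meant among the compounds shown, and "the series" means these compounds.

Working notes on the series. Compound 1 `CN(C)CCCOc1ccc(CN(C)c2nc3ccc(Oc4ccc(C(F)(F)F)cc4)cc3s2)cc1`, compound 2 `CN(Cc1ccc(OCCCNC(=N)N)cc1)c1nc2ccc(Oc3ccc(C(F)(F)F)cc3)cc2s1` and compound 3 `N=C(N)NCCCOc1ccc(CNc2nc3ccc(Oc4cccc(C(F)(F)F)c4)cc3s2)cc1` share a core and carry a tail on a saturated chain carbon, three bonds along the chain from an oxygen on an aromatic ring. In an assay on cells for inhibition of Voltage-dependent T-type calcium channel subunit alpha-1H (Homo sapiens), read by FLIPR and calcium flux, with stated times of 600 s and 300 s (a lower number here means a stronger inhibitor, a higher number a weaker inhibitor), compound 1 gives 54000 nM. In this assay compound 2 gives 212000 nM. In this assay compound 3 gives 270000 nM. The change from compound 2 to compound 1 is a group of 3 heavy atoms (2 carbon, 1 nitrogen; no ring) in place of a group of 4 heavy atoms (1 carbon, 3 nitrogen; no ring), on a saturated chain carbon, three bonds along the chain from an oxygen on an aromatic ring and it produced a 3.9-fold lower number from compound 2 to compound 1 (0.59 log units; beyond the scatter). How the core of compound 3 differs from that of compound 2 is not broken down here; their two numbers in this assay lie within the scatter of one another, whereas the gap between compound 3 and compound 1 lies beyond it.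

Compound 4 `CN(C)CCCOc1ccc(CNc2nc3ccc(Oc4cccc(C(F)(F)F)c4)cc3s2)cc1` has not yet been measured. It differs from compound 3 by a group of 3 heavy atoms (2 carbon, 1 nitrogen; no ring) in place of a group of 4 heavy atoms (1 carbon, 3 nitrogen; no ring), on a saturated chain carbon, three bonds along the chain from an oxygen on an aromatic ring, the same change as from compound 2 to compound 1 at the same place. The step from compound 3 to compound 4 in this assay is expected to be a 3.9-fold lower number from compound 3 to compound 4 (0.59 log units; beyond the scatter). This expectation rests on the earlier observation that a 3.9-fold lower number from compound 2 to compound 1 (0.59 log units; beyond the scatter) followed the same change. Compound 4 is therefore estimated at 70000 nM in this assay. For the measured compounds named here, the expected range for compound 4 runs from 25000 nM to 200000 nM; only one prior instance of this change is available, so the range is kept wide. Measured value to follow.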

Compound 4, half-maximal inhibitory concentration: 110000 nM
For compound 4 the middle estimate is 1.6-fold (0.20 log units) below the measured one; measured number inside the range.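

In this assay, dimethylamino in place of the group of 4 heavy atoms, on a saturated chain carbon, three bonds along the chain from an oxygen on an aromatic ring, gives a 2.5-fold lower number from compound 3 to compound 4 (0.39 log units; beyond the scatter), the same direction as on the other core. The two steps do not differ in size beyond what repeated measurement allows, so within this pair of cores the change carries over with its direction and approximate size intact: the same change on two cores in this assay, a 3.9-fold lower number (0.59 log units; beyond the scatter) from compound 2 to compound 1 and a 2.5-fold lower number (0.39 log units; beyond the scatter) from compound 3 to compound 4, 1.6-fold (0.20 log units) apart, within the scatter of two such steps. For the compounds shown here, this rests on only two matched pairs, however, and it does not show that the change would carry over to any further core, nor does it explain why the number falls; how the two cores differ is not broken down here, so no part of either core can be tied to the step.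

The compounds shown leave open whether a primary amine, a carboxylic acid or a morpholine at the end of this tail would follow dimethylamino or the group it replaced. Also open, going by these compounds, is whether a shorter or longer chain would alter the step, and whether the same change would hold on a core carrying a group other than trifluoromethyl.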